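The source may report more compounds than this note shows. Statements on the series, on what has been measured and on what is new or still open speak of the compounds shown alone.

For the measured compounds named here, in an ADME assay on L1210/0 cells (Mus musculus) for cytotoxicity, with a stated time of 48 h (a lower number here means a stronger inhibitor, a higher number a weaker inhibitor), compound 1 `OCCOCn1cnc2c(S)nc(F)nc21` gives 170000 nM, the higher of the two numbers measured so far, which makes it the weaker inhibitor of the pair. The other measured compound, compound 2 `CC(=O)OCCOCn1cnc2c(S)nc(F)nc21`, gives 40000 nM. Compound 3 `CC(O)Cn1cnc2c(S)nc(F)nc21` has not yet been measured. It keeps the core of compound 1 and differs in the side chain: 1-hydroxyethyl in place of 2-hydroxyethoxy on a saturated chain carbon bound to an aromatic nitrogen. Cut one bond further out, the same difference reads (2-hydroxyethoxy)methyl to 2-hydroxypropyl.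

Going by the values given here, only one measured step offers any guidance. This is a 4.3-fold lower number from compound 1 to compound 2 (0.63 log units; beyond the scatter), a modest change that puts acetyl in place of hydrogen on an oxygen on a saturated carbon. Among the compounds with values here, it is a different kind of change from the one in compound 3, so it sets only a rough scale, and no measured compound shows what replacing the chain itself does. No step beyond the scatter is therefore expected in this assay, and no firm direction can be given. The expected step is a 1.1-fold lower number from compound 1 to compound 3 (0.05 log units; within the scatter). Compound 3 is estimated at 150000 nM, with an expected range of 60000 nM to 350000 nM.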

Compound 3, half-maximal inhibitory concentration: > 200000 nM
Compound 3: a limit, no number; the forecaster's own chance of this, stated with the estimate: 15%; middle value at least 1.3-fold (0.12 log units) from the limit.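

In this assay, compound 3 gives > 200000 nM, which is a limit of the assay and not a number. For the compounds shown here, putting 1-hydroxyethyl in place of 2-hydroxyethoxy on a saturated chain carbon bound to an aromatic nitrogen gives an at least 1.1-fold higher number from compound 1 to compound 3 (0.07 log units; that floor lies within the scatter), the first measured change of the chain itself, and unlike the acetyl change, which gave a 4.3-fold lower number from compound 1 to compound 2 (0.63 log units; beyond the scatter), it brings no lower number. How far this chain change really moves the number cannot be read from that floor, and the reading ends at a limit: the limit of > 200000 nM in this assay, at which 1 of the 3 values shown sits.

The compounds shown leave open which part of the difference between (2-hydroxyethoxy)methyl and 2-hydroxypropyl matters, and whether acetyl on the oxygen of compound 3 would lower the number as it does for compound 1. They also leave open whether an amine, a carboxylic acid or a longer chain in place of 2-hydroxyethoxy would reach a lower number than compound 2 at 40000 nM.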